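The compounds below may be only part of what the source reports. "The series", "measured", "known", "first", "only" and "open" are said of these compounds alone.

Compound 1 `O=S(=O)(/C=C/c1ccc(F)cc1)Cc1ccc(Nc2ncnc3ccccc23)cc1` gives the lower of the two numbers in a functional assay on SK-OV-3 cells (Homo sapiens) (on this read-out lower numbers stand for stronger inhibition of growth and higher numbers for weaker inhibition of growth), at 2000 nM, while compound 2 `O=S(=O)(/C=C/c1ccc(F)cc1Cl)Cc1ccc(Nc2ncnc3ccccc23)cc1` gives 44000 nM. For the measured compounds named here, the one measured step, a 22-fold higher number from compound 1 to compound 2 (1.34 log units; beyond the scatter), concerns a different change. Compound 3 `O=S(=O)(/C=C/c1ccc(O)cc1)Cc1ccc(Nc2ncnc3ccccc23)cc1` differs from compound 1 by hydroxy in place of fluoro on an aromatic carbon. Going by the values given here, no measured step bears directly on this change, so the only anchor is compound 1 itself with 2000 nM. A modest weakening is expected, a 1.5-fold higher number from compound 1 to compound 3 (0.18 log units; within the scatter), though an outcome within the scatter would not surprise. Compound 3 is therefore estimated at 3000 nM, within 700 nM to 13000 nM.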

Compound 3, concentration for 50% growth inhibition: 14000 nM
The estimate for compound 3 lay 4.7-fold (0.67 log units) below the measured number; the whole stated range lies below it.
By their numbers in this assay, from the lowest: compound 1; then compound 3; then compound 2.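

In this assay, the aromatic carbon para to a large group proves sensitive to its substituent, a change the earlier pair did not touch: hydroxy in place of fluoro gives a 7.0-fold higher number from compound 1 to compound 3 (0.85 log units; beyond the scatter) and so weakens growth inhibition. Replacing 2-chloro-4-fluorophenyl with 4-hydroxyphenyl gives a 3.1-fold lower number from compound 2 to compound 3 (0.50 log units; beyond the scatter), but this step alters two ring substituents together and does not separate their contributions. Nothing available explains either step. Still open, as far as these compounds go, is how methoxy or an amine at this carbon would compare with fluoro and hydroxy.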